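A pyrimidine swap on the amide of compound 1

A few compounds are considered here, and "the series" means these few. Any claim that something is new, unique, unknown or untested is made for them only; others in the source may bear on it.

For the measured compounds named here, in an ADME assay on LLC-MK2 cells (Macaca mulatta) for cytotoxicity, read by spectrophotometry and crystal violet staining, with a stated time of 4 days (a higher number here means that more compound is tolerated, a lower number that less compound is tolerated), compound 1 (`CC(C)n1ncc2c(C(=O)Nc3ncccn3)cc(-c3cccs3)nc21`) gives 75000 nM and holds the higher of the two numbers so far. Compound 2 (`CC(C)n1ncc2c(C(=O)Nc3ccccn3)cc(-c3ccsc3)nc21`) gives 25000 nM as the lower one, and the gap between these two compounds lies beyond the scatter. Compound 3 (`CC(C)n1ncc2c(C(=O)Nc3cncnc3)cc(-c3cccs3)nc21`) has the same atoms, with pyrimidin-5-yl in place of pyrimidin-2-yl on an amide-type nitrogen. Going by the values given here, no measured pair shows this change alone, so an estimated 1.3-fold lower number from compound 1 to compound 3 (0.10 log units; within the scatter) is expected in this assay and would be no step beyond the scatter. For compound 3 the estimated value is 60000 nM (expected range 22000 nM to 150000 nM).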

Compound 3, half-maximal cytotoxic concentration: 20000 nM
Beside the measured number, compound 3's estimate is 3.0-fold (0.48 log units) above it; measured number outside the range, below it.
By their numbers in this assay, from the lowest: compounds 3 and 2 (each within the scatter of the next); then compound 1.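

Joining the pyrimidine to the amide-type nitrogen through a different ring atom, with the same atoms overall, gives a 3.8-fold lower number from compound 1 to compound 3 (0.57 log units; beyond the scatter) in this assay. For the compounds shown here, compound 1 and compound 2 differ in more than one place, so this is the first single change that can be read. At this position, the way the ring is joined matters, even though pyrimidin-2-yl and pyrimidin-5-yl have the same counts of heavy atoms and hydrogen-bond acceptors.

No measurement shown gives a reason for this step. On these data alone, how a pyrazin-2-yl group on the same amide-type nitrogen would compare remains open.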